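The compounds below may be only part of what the source reports. "The series", "measured", "known", "first", "only" and "open" are said of these compounds alone.

Compound 3 `O=C(CCCCCCc1ccccc1)c1nc(C(=O)C(F)(F)F)co1` gives the lowest number of the three measured compounds: in an assay on HEK-293T cells for inhibition of diacylglycerol lipase-alpha (Homo sapiens), read by colorimetric assay (on this read-out lower numbers stand for stronger inhibition and higher numbers for weaker inhibition), compound 3 gives 123 nM. Compound 2 `O=C(CCCCCc1ccccc1)c1nc2ccc(F)cc2o1` gives 708 nM in this assay, the nearest value, with a gap beyond the scatter; compound 1 `O=C(CCCCCc1ccccc1)c1nc2ccccc2[nH]1` gives 12000 nM, the furthest from compound 3, also beyond the scatter. Compound 4 `CC(=O)c1coc(C(=O)CCCCCCc2ccccc2)n1` has not been measured in this assay. It differs from compound 3 in one place: methyl in place of trifluoromethyl on a carbonyl carbon. Going by the values given here, no step between measured compounds of this kind exists, so the expectation rests on the structural change alone. The step is expected to weaken inhibition beyond the scatter, estimated as a 12-fold higher number from compound 3 to compound 4 (1.09 log units; beyond the scatter). In this assay compound 4 is expected at 1500 nM, with a range of 400 nM to 6000 nM.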

Compound 4, half-maximal inhibitory concentration: 123 nM
Beside the measured number, compound 4's estimate is 12-fold (1.09 log units) above it; measured number below the stated range.
By their numbers in this assay, from the lowest: compounds 3 and 4 (each within the scatter of the next); then compound 2; then compound 1.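

In this assay, the change to methyl on a carbonyl carbon gives no change at the digits printed from compound 3 to compound 4 (within the scatter). The trifluoromethyl is therefore not needed at this position to hold the level of inhibition seen with compound 3, and the acetyl serves as well in this assay. Nothing available explains why the two groups match. Still open, as far as these compounds go, is whether an ethyl, a cyclopropyl or an amine on this carbonyl carbon would hold that level. Also open, from the compounds shown here alone, is what happens when the whole acetyl is replaced by a carboxylic acid or a nitrile.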